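Chlorophenyl for dimethoxyphenyl on the second core

The source may report more compounds than this note shows. Statements on the series, on what has been measured and on what is new or still open speak of the compounds shown alone.

Three compounds of the series have been run in a functional assay on U-87MG ATCC cells for antiproliferative activity against U-87 MG (Homo sapiens), read by MTT assay, with a stated time of 48 h; a lower number here means a stronger inhibitor, a higher number a weaker inhibitor. Compound 2 `COc1ccc(-c2nc(C)c(C(=O)CSc3nc(-c4ccc(OC)c(OC)c4)c(C#N)c(=O)[nH]3)s2)cc1` gives 12500 nM. Compound 1 `COc1ccc(-c2nc(C)c(C(=O)CSc3nc(-c4ccc(Cl)cc4)c(C#N)c(=O)[nH]3)s2)cc1` differs from it by 4-chlorophenyl in place of 3,4-dimethoxyphenyl on an aromatic carbon and gives 45900 nM, a step of a 3.7-fold higher number from compound 2 to compound 1 (0.56 log units; beyond the scatter). Compound 3 `COc1ccc(-c2nc(SCC(=O)c3sc(-c4ccccc4)nc3C)[nH]c(=O)c2C#N)cc1OC` carries a different core; the difference between the two cores is hydrogen in place of methoxy on an aromatic carbon, and in this assay compound 3 gives 15300 nM, with the step of a 1.2-fold higher number from compound 2 to compound 3 (0.09 log units; within the scatter) lying within the scatter.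

Compound 4 `Cc1nc(-c2ccccc2)sc1C(=O)CSc1nc(-c2ccc(Cl)cc2)c(C#N)c(=O)[nH]1` has not yet been measured. It differs from compound 3 by 4-chlorophenyl in place of 3,4-dimethoxyphenyl on an aromatic carbon, the same change seen from compound 2 to compound 1, at a place described in the same words in both cases. Among the compounds with values here, the only guide is that earlier step of a 3.7-fold higher number from compound 2 to compound 1 (0.56 log units; beyond the scatter), made on a core that differs by hydrogen in place of methoxy on an aromatic carbon. Within the data shown here, with that as the sole precedent, the expectation for compound 4 in this assay is a step of about a 3.3-fold higher number from compound 3 to compound 4 (0.51 log units; beyond the scatter) from compound 3, a weakening of similar size. The estimated value for compound 4 is therefore 50000 nM, with a range from 20000 nM to 130000 nM.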

Compound 4, half-maximal inhibitory concentration: 43400 nM
Estimate against measurement, compound 4: 1.2-fold (0.06 log units) above; the measured number falls inside the stated range.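

In this assay, 4-chlorophenyl in place of 3,4-dimethoxyphenyl carries over to the second core as a 2.8-fold higher number from compound 3 to compound 4 (0.45 log units; beyond the scatter), and the two steps agree: the same change on two cores in this assay, a 3.7-fold higher number (0.56 log units; beyond the scatter) from compound 2 to compound 1 and a 2.8-fold higher number (0.45 log units; beyond the scatter) from compound 3 to compound 4, 1.3-fold (0.11 log units) apart, within the scatter of two such steps. The core difference, hydrogen in place of methoxy on an aromatic carbon, also reads the same with 4-chlorophenyl present, at a 1.1-fold lower number from compound 1 to compound 4 (0.02 log units; within the scatter), and the two steps for that change agree: the same change on two cores in this assay, a 1.2-fold higher number (0.09 log units; within the scatter) from compound 2 to compound 3 and a 1.1-fold lower number (0.02 log units; within the scatter) from compound 1 to compound 4, 1.3-fold (0.11 log units) apart, within the scatter of two such steps. Across these four compounds the two changes therefore behave as independent of each other, but this rests on a single pair of cores in one cell assay and does not show that the step would hold on any other core or explain why it arises.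

The compounds shown do not separate the effect of the incoming chlorine from the loss of the two methoxy groups, which a plain phenyl at this place would help to resolve. As far as these compounds go, it also remains open how an amine or a carboxylic acid on that ring would fare on either core.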